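Swapping a Phenoxymethyl for a Hydroxycyclohexyl on the Alkyne

A few compounds are considered here, and "the series" means these few. Any claim that something is new, unique, unknown or untested is made for them only; others in the source may bear on it.

Compound 2, `O=[N+]([O-])c1c(CS(=O)(=O)c2ccccc2)nc2c(C#CCOc3ccccc3)cc(Cl)cn12`, was tested in an ADME assay on HepG2 cells (Homo sapiens) for cytotoxicity, read by MTT assay, with a stated time of 72 h (a lower number here means that less compound is tolerated, a higher number that more compound is tolerated), where compound 2 gives 8400 nM. Among the two plain numbers shown this is the lower one, and compound 3, `O=[N+]([O-])c1c(CS(=O)(=O)c2ccccc2)nc2c(C#CCO)cc(Cl)cn12`, gives 10100 nM in this assay. Compound 1, `O=[N+]([O-])c1c(CS(=O)(=O)c2ccccc2)nc2c(C#Cc3cccnc3)cc(Cl)cn12`, gives only a limit in this assay, > 3900 nM. Within the data shown here, the one fully readable step, a 1.2-fold higher number from compound 2 to compound 3 (0.08 log units; within the scatter), puts hydrogen in place of phenyl on an oxygen on a saturated carbon and stays within the scatter. The steps a step that the limit leaves unreadable from compound 1 to compound 2 and a step that the limit leaves unreadable from compound 1 to compound 3 cannot be sized because of the limit of > 3900 nM in this assay, at which 1 of the 3 values shown sits.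

Compound 4, `O=[N+]([O-])c1c(CS(=O)(=O)c2ccccc2)nc2c(C#CC3(O)CCCCC3)cc(Cl)cn12`, differs from compound 2 by 1-hydroxycyclohexyl in place of phenoxymethyl on a triple-bonded carbon. Among the measured compounds shown here, the only readable step for comparison, a 1.2-fold higher number from compound 2 to compound 3 (0.08 log units; within the scatter), also took the phenyl ring away from the group on a triple-bonded carbon without leaving the scatter, so no step beyond the scatter is expected here either. Compound 4 is therefore expected to give about 9000 nM in this assay, with a range from 4000 nM to 20000 nM, which corresponds to an expected step of a 1.1-fold higher number from compound 2 to compound 4 (0.03 log units; within the scatter).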

Compound 4, half-maximal cytotoxic concentration: > 25000 nM
Compound 4 gave a limit, no number; the forecaster's own chance of this, stated with the estimate: 20%; middle value at least 2.7-fold (0.44 log units) from the limit.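

In this assay compound 4 gives > 25000 nM, which is a limit and not a number. At this triple-bonded carbon, 1-hydroxycyclohexyl gives the only readable changes beyond the scatter among the compounds shown, with an at least 2.9-fold higher number from compound 2 to compound 4 (0.47 log units; beyond the scatter) and an at least 2.4-fold higher number from compound 3 to compound 4 (0.39 log units; beyond the scatter). Compound 3 also carries a hydroxyl group on its hydroxymethyl, yet only compound 4, with its six-membered non-aromatic ring, separates from compound 2 beyond the scatter.

From the compounds shown here alone, the step from compound 1 to compound 4 cannot be read, and how far compound 4 lies past its limit stays open. Also open, going by these compounds, is whether the ring alone is enough, which cyclohexyl without the hydroxyl group would test, and whether an amine in place of that hydroxyl group would give the same result.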